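A few compounds are considered here, and "the series" means these few. Any claim that something is new, unique, unknown or untested is made for them only; others in the source may bear on it.

Compound 1 `CONc1nc(C#CC2CCCCC2O)nc2c1ncn2[C@@H]1O[C@H](CO)[C@@H](O)[C@H]1O` and compound 2 `CONc1nc(C#Cc2ccccn2)nc2c1ncn2[C@@H]1O[C@H](CO)[C@@H](O)[C@H]1O` share one core and differ only in the group attached to a triple-bonded carbon. In an assay on CHO cells for displacement of a labelled ligand from adenosine receptor A3 (Homo sapiens) (on this read-out higher numbers stand for weaker inhibition and lower numbers for stronger inhibition), compound 1 gives 1.7 nM, and compound 2 gives 2.3 nM. Among the measured compounds shown here, compound 2 thus stands at the higher of the two numbers so far, but the step of a 1.4-fold higher number from compound 1 to compound 2 (0.13 log units; within the scatter) is within the scatter, so the two compounds cannot be told apart on this basis. Compound 3 `CONc1nc(C#Cc2cccc(C(F)(F)F)c2)nc2c1ncn2[C@@H]1O[C@H](CO)[C@@H](O)[C@H]1O` has not yet been measured; it arises from compound 2 by the change (3-(trifluoromethyl)phenyl in place of pyridin-2-yl on a triple-bonded carbon). For the measured compounds named here, only one measured step bears on this position, a 1.4-fold higher number from compound 1 to compound 2 (0.13 log units; within the scatter), in which replacing one group on that carbon by a quite different one changed the number within the scatter. A step of a 1.3-fold higher number from compound 2 to compound 3 (0.12 log units; within the scatter) is therefore expected, nothing beyond the scatter. Compound 3 is estimated at 3 nM, with a range from 0.9 nM to 10 nM.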

Compound 3, inhibition constant: 23 nM
Compound 3: middle estimate off by 7.7-fold (0.88 log units), on the low side, outside the stated range (above it).
By their numbers in this assay, from the lowest: compounds 1 and 2 (each within the scatter of the next); then compound 3.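

At this position the group does matter. In this assay, among the compounds shown here, 3-(trifluoromethyl)phenyl in place of pyridin-2-yl gives a step beyond the scatter (a 10-fold higher number from compound 2 to compound 3 (1.00 log units; beyond the scatter)), and in place of 2-hydroxycyclohexyl it gives a larger one (a 14-fold higher number from compound 1 to compound 3 (1.13 log units; beyond the scatter)), whereas the only earlier step here stayed within the scatter. The close numbers of compound 1 and compound 2 therefore did not mean that any group on this triple-bonded carbon is accepted, and no measurement at hand explains the higher number of compound 3.

The compounds shown leave open whether the change follows from the carbon-only ring or from the trifluoromethyl group it carries. A plain phenyl would separate these two, and a phenyl bearing a chlorine or a methoxy group would show whether other substituents act alike.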